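This account rests on a few compounds, and the source may have more. Where it says the series, first, only, none or still open, it means among the compounds named here.

Going by the values given here, in a functional assay on HT-29 cells (Homo sapiens) for cytotoxicity, read by MTT assay, with a stated time of 72 h (on this read-out lower numbers stand for stronger inhibition and higher numbers for weaker inhibition), compound 2 (`O=C(CN1CCN(c2nnc(Cc3ccccc3)c3ccccc23)CC1)Nc1cc(C(F)(F)F)ccc1Cl`) stands highest of the two numbers so far at 66800 nM against compound 1 (`O=C(CN1CCN(c2nnc(Cc3ccccc3)c3ccccc23)CC1)Nc1ccc(F)c(F)c1`) at 9510 nM in the same test. Compound 3 (`O=C(CN1CCN(c2nnc(Cc3ccccc3)c3ccccc23)CC1)Nc1cccc(Br)c1`) has 3-bromophenyl in place of 2-chloro-5-(trifluoromethyl)phenyl on an amide-type nitrogen. Among the compounds with values here, the only measured step at that place (a 7.0-fold higher number from compound 1 to compound 2 (0.85 log units; beyond the scatter)) is modest but beyond the scatter, and a single step is a thin guide. A step to a lower number in this assay is expected, somewhat smaller than that one (a 3.7-fold lower number from compound 2 to compound 3 (0.57 log units; beyond the scatter)). For compound 3 the estimated value is 18000 nM with an expected range from 6000 nM to 55000 nM in this series.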

Compound 3, half-maximal inhibitory concentration: 13400 nM
The estimate for compound 3 lay 1.3-fold (0.13 log units) above the measured number; measured number inside the range.
By their numbers in this assay, from the lowest: compounds 1 and 3 (each within the scatter of the next); then compound 2.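

In this assay, 3-bromophenyl in place of 2-chloro-5-(trifluoromethyl)phenyl gives a 5.0-fold lower number from compound 2 to compound 3 (0.70 log units; beyond the scatter), while 3-bromophenyl in place of 3,4-difluorophenyl gives a 1.4-fold higher number from compound 1 to compound 3 (0.15 log units; within the scatter), so these two groups are not told apart here. Of the three aryl groups at this amide-type nitrogen, only 2-chloro-5-(trifluoromethyl)phenyl stands apart, beyond the scatter from both others. No supporting measurement bears on this result.

Whether the chlorine or the trifluoromethyl accounts for the higher number of compound 2 stays open. So does the effect of an amine, a carboxylic acid or a longer chain at this place.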